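Trimming a Methoxy from the Aryl Ketone End

The source may report more compounds than this note shows. Statements on the series, on what has been measured and on what is new or still open speak of the compounds shown alone.

Compound 1, `COc1cc(-c2cc(/C=C/C(=O)c3ccc(N)cc3)[nH]n2)cc(OC)c1OC`, in a functional assay on COLO 205 cells (Homo sapiens) for inhibition, read by sulforhodamine B assay, with a stated time of 48 h (on this read-out lower numbers stand for stronger inhibition of growth and higher numbers for weaker inhibition of growth), gives 3340 nM.
Compound 2, `COc1cc(-c2cc(/C=C/C(=O)c3ccc(Cl)c(Cl)c3)[nH]n2)cc(OC)c1OC`, in this assay gives 15800 nM.
Compound 3, `COc1ccc(C(=O)/C=C/c2cc(-c3cc(OC)c(OC)c(OC)c3)n[nH]2)cc1OC`, in this assay gives 3210 nM.

Compound 3 carries the lowest number of the three in this assay, but its gap to compound 1 is within the scatter, so the two cannot be ordered; only compound 2 stands apart, with a 4.9-fold lower number from compound 2 to compound 3 (0.69 log units; beyond the scatter). The step of a 1.0-fold lower number from compound 1 to compound 3 (0.02 log units; within the scatter) shows that exchanging the group on the carbonyl carbon can also leave the number unchanged.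

Compound 4, `COc1ccc(C(=O)/C=C/c2cc(-c3cc(OC)c(OC)c(OC)c3)n[nH]2)cc1`, is the next step from compound 3: hydrogen in place of methoxy on an aromatic carbon. Read one bond further out, this is 3,4-dimethoxyphenyl to 4-methoxyphenyl. No measured pair removes a methoxy from this ring; the steps shown only exchange one whole aryl group for another, and two of the three groups tried give numbers within the scatter of each other in this assay. Because of a 1.0-fold lower number from compound 1 to compound 3 (0.02 log units; within the scatter) the ring appears tolerant of change, so for compound 4 a step of a 1.2-fold higher number from compound 3 to compound 4 (0.10 log units; within the scatter) is expected, toward a slightly higher number but likely within the scatter. Compound 4 is therefore estimated at 4000 nM, with a range from 1500 nM to 12000 nM.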

Compound 4, concentration for total growth inhibition: 3240 nM
Compound 4: the middle estimate sits 1.2-fold (0.09 log units) above what was measured, and the stated range covers the measured number.
By their numbers in this assay, from the lowest: compounds 3, 4 and 1 (each within the scatter of the next); then compound 2.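

In this assay, among the compounds shown here, removing one methoxy from the 3,4-dimethoxyphenyl group leaves the number where it was (a 1.0-fold higher number from compound 3 to compound 4 (0.00 log units; within the scatter)), and this is the first pair in which a single methoxy on this ring is removed rather than a whole aryl group exchanged. The 4-methoxyphenyl group also stands apart from the 3,4-dichlorophenyl group (a 4.9-fold lower number from compound 2 to compound 4 (0.69 log units; beyond the scatter)) but shows no readable difference from the 4-aminophenyl group when methoxy takes the place of amino (a 1.0-fold lower number from compound 1 to compound 4 (0.01 log units; within the scatter)), so among the four aryl groups only the 3,4-dichlorophenyl group separates from the others. Nothing shown gives a reason for this flat result on the ring.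

The compounds shown leave open whether the ring needs any group on it at all, which a plain phenyl ketone would test, and whether a single chlorine gives a number like that of compound 2 or like those of the other three. They also leave open whether the flat result would hold for a larger or charged group on this ring, such as a carboxylic acid or a morpholine.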